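From a 3-fluorophenyl to a 4-iodophenyl on the ring nitrogen

A few compounds are considered here, and "the series" means these few. Any claim that something is new, unique, unknown or untested is made for them only; others in the source may bear on it.

Three compounds sharing one core were measured in an assay on CHO cells for displacement of a labelled ligand from adenosine receptor A2b (Homo sapiens), read by scintillation counting, with a stated time of 75 min, in the presence of a further agent that is not named here; a lower number here means a stronger inhibitor, a higher number a weaker inhibitor:

compound 1, `CCCn1c(=O)[nH]c2nc(-c3ccc(S(=O)(=O)N4CCN(Cc5cccc(C)c5)CC4)cc3)[nH]c2c1=O`, gives 0.397 nM
compound 2, `CCCn1c(=O)[nH]c2nc(-c3ccc(S(=O)(=O)N4CCN(Cc5cccc(Br)c5)CC4)cc3)[nH]c2c1=O`, gives 0.148 nM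
compound 3, `CCCn1c(=O)[nH]c2nc(-c3ccc(S(=O)(=O)N4CCN(c5cccc(F)c5)CC4)cc3)[nH]c2c1=O`, gives 0.632 nM

Compound 3 shows the highest number of the three. Its distance to compound 1 is small, a 1.6-fold higher number from compound 1 to compound 3 (0.20 log units; within the scatter), and lies within the scatter, so the two cannot be ordered. Its distance to compound 2 is larger, a 4.3-fold higher number from compound 2 to compound 3 (0.63 log units; beyond the scatter), and lies beyond it.

Compound 4, `CCCn1c(=O)[nH]c2nc(-c3ccc(S(=O)(=O)N4CCN(c5ccc(I)cc5)CC4)cc3)[nH]c2c1=O`, carries 4-iodophenyl in place of 3-fluorophenyl on an amine nitrogen in a ring. For the measured compounds named here, no measured step repeats this change. The closest guide is the step in which a bromo took the place of a methyl on an aromatic carbon, a 2.7-fold lower number from compound 1 to compound 2 (0.43 log units; beyond the scatter), a modest move to a lower number. The two steps that reach compound 3 each change both the halogen and the link to the ring nitrogen, and so bear only loosely on the present change.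

On this basis compound 4 is expected to give a somewhat lower number than compound 3, with the step estimated as a 1.8-fold lower number from compound 3 to compound 4 (0.26 log units; within the scatter). The estimate for compound 4 in this assay is 0.35 nM, within a range of 0.12 nM to 1 nM.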

Compound 4, inhibition constant: 0.159 nM
Estimate against measurement, compound 4: 2.2-fold (0.34 log units) above, and the stated range covers the measured number.
By their numbers in this assay, from the lowest: compounds 2 and 4 (each within the scatter of the next); then compounds 1 and 3 (each within the scatter of the next).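

In this assay, the step between the two phenyl compounds is a 4.0-fold lower number from compound 3 to compound 4 (0.60 log units; beyond the scatter) and lies beyond the scatter, showing that the number at this ring nitrogen responds to the substituent on the phenyl ring even when the phenyl link stays the same. A phenyl on this nitrogen does not by itself set the number apart from a benzyl: the 4-iodophenyl compared with the 3-bromobenzyl gives a 1.1-fold higher number from compound 2 to compound 4 (0.03 log units; within the scatter) and stays within the scatter, while the 4-iodophenyl compared with the 3-methylbenzyl gives a 2.5-fold lower number from compound 1 to compound 4 (0.40 log units; beyond the scatter) and lies beyond it, in the direction of the lower number. No measurement offered here bears on what lies behind these differences.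

The change from compound 3 to compound 4 alters both the halogen and its place on the phenyl ring, so the compounds shown leave open which of the two carries the step. A 3-iodophenyl or a 4-fluorophenyl on the same nitrogen would separate them, and an unsubstituted phenyl would show what either halogen contributes.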